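Estimating Compound 3 from Two Weak Cytotoxic Analogues

The source may report more compounds than this note shows. Statements on the series, on what has been measured and on what is new or still open speak of the compounds shown alone.

compound 1 `COc1ccc(Cn2cc(/C=N\NC(=O)c3c[nH]c4ccc(Br)cc34)c3ccc(F)cc32)cc1`: 21800 nM
compound 2 `O=C(N/N=C\c1cn(Cc2ccc(Cl)cc2)c2cc(F)ccc12)c1c[nH]c2ccc(Br)cc12`: 12400 nM

In a functional assay on PC-3 cells (Homo sapiens) for cytotoxicity (a lower number here means a stronger inhibitor, a higher number a weaker inhibitor), compound 1 gives 21800 nM and compound 2 gives 12400 nM. Going by the values given here, compound 1 has the highest of the two numbers, and the single measured step, a 1.8-fold lower number from compound 1 to compound 2 (0.25 log units; within the scatter), lies within the scatter. Compound 3 `COc1ccc(Cn2cc(/C=N\NC(=O)c3cn(C)c4ccccc34)c3ccc(F)cc32)cc1` differs from compound 1 by 1-methyl-1H-indol-3-yl in place of 5-bromo-1H-indol-3-yl on a carbonyl carbon. Among the compounds with values here, no measured step touches this part of the molecule, so nothing here points to a shift beyond the scatter in this assay. For compound 3 the expected value is 30000 nM (range 8000 nM to 100000 nM), which would correspond to an expected step of a 1.4-fold higher number from compound 1 to compound 3 (0.14 log units; within the scatter).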

Compound 3, half-maximal inhibitory concentration: 12800 nM
The estimate for compound 3 lay 2.3-fold (0.37 log units) above the measured number, and the stated range covers the measured number.
By their numbers in this assay, from the lowest: compounds 2, 3 and 1 (each within the scatter of the next).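

Putting 1-methyl-1H-indol-3-yl in place of 5-bromo-1H-indol-3-yl on the carbonyl carbon gives, in this assay, a 1.7-fold lower number from compound 1 to compound 3 (0.23 log units; within the scatter). Going by these compounds alone, this is the first look at this part of the molecule, and the swap, which also takes away a hydrogen-bond donor, stays within the scatter. No measured property is available to explain this result.

Since the bromine and the methyl differ in one step, their separate contributions cannot be told apart. Going by these compounds, what an amine or a carboxylic acid on this indole would do remains open.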